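The source may hold more compounds than are shown below. What is called first, only, known or untested is meant among the compounds shown, and "the series" means these compounds.

Compound 2, `CCN(CC)C(=O)Nc1ccc2cc[nH]c2c1`, sits at the ceiling of the numbers shown: in an assay on isolated protein for inhibition of Amine oxidase [flavin-containing] B (Homo sapiens), read by fluorescence, with stated times of 10 min, 10 s and 20 min (on this read-out lower numbers stand for stronger inhibition and higher numbers for weaker inhibition), compound 2 gives > 100000 nM, which is a limit of the assay rather than a number. Compound 1, `CCN(CC)C(=O)Nc1ccc2[nH]ccc2c1`, likewise gives only > 100000 nM in this assay, again a limit. Going by the values given here, the single numeric value comes from compound 3, `C#CCn1ccc2cc(NC(=O)N(CC)CC)ccc21`, which in this assay gives 28800 nM. Among the compounds with values here, the one measured step that bears on the question is an at least 3.4-fold lower number from compound 1 to compound 3 (0.54 log units; beyond the scatter), a change that turns a limit into a number. Compound 4, `C#CCn1ccc2ccc(NC(=O)N(CC)CC)cc21`, differs from compound 2 in the same manner: propargyl in place of hydrogen on an aromatic nitrogen. Because two of the three values stand at the limit of > 100000 nM in this assay, at which 2 of the 3 values shown sit, the true size of that step can only be bounded from below. Compound 4 is therefore expected to show a lowering of an at least 3.3-fold lower number from compound 2 to compound 4 (0.52 log units; beyond the scatter), in keeping with an at least 3.4-fold lower number from compound 1 to compound 3 (0.54 log units; beyond the scatter). Compound 4 is estimated to give 30000 nM in this assay, with a range from 8000 nM to 100000 nM.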

Compound 4, half-maximal inhibitory concentration: 2620 nM
Compound 4: the middle estimate sits 11-fold (1.06 log units) above what was measured; the measured number lies below the stated range.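

On the core of compound 2, propargyl in place of hydrogen on an aromatic nitrogen gives a large step in this assay, an at least 38-fold lower number from compound 2 to compound 4 (1.58 log units; beyond the scatter). With compound 4, the change has now brought a second core from a limit to a measured number, so the lowering seen on the core of compound 1 is not confined to that core. How far the two steps truly differ cannot be read: the same change on two cores in this assay, an at least 3.4-fold lower number (0.54 log units; beyond the scatter) from compound 1 to compound 3 and an at least 38-fold lower number (1.58 log units; beyond the scatter) from compound 2 to compound 4; the limit leaves it open whether they differ

The compounds shown leave open whether the triple bond of propargyl is needed, since a plain propyl chain or a longer chain such as butynyl on that nitrogen could give a similar or a different number. They also leave open how much of the true size of each step lies hidden behind the ceiling of the assay: the limit of > 100000 nM in this assay, at which 2 of the 4 values shown sit.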